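Hydroxamate series: benzyl to propyl on the pyrazole-type core

The compounds below may be only part of what the source reports. "The series", "measured", "known", "first", "only" and "open" are said of these compounds alone.

Measured so far:
compound 1 `Cc1cc(-c2ccc(F)cc2)nn1Cc1ccc(C(=O)NO)cc1`, 8 nM
compound 2 `O=C(NO)c1ccc(Cn2nc(Cc3ccccc3)cc2-c2ccc(F)cc2)cc1`, 420 nM
compound 3 `O=C(NO)c1ccc(CNC(=O)c2cc(-c3ccc(F)cc3)[nH]n2)cc1`, 1 nM

In an assay on cells for inhibition of protein deacetylase HDAC6 (Homo sapiens), read by fluorescence, with stated times of 15 min and 60 min (a higher number here means a weaker inhibitor, a lower number a stronger inhibitor), compound 2 stands at the top of the three numbers, well separated from compound 1 and further still from compound 3; both gaps lie beyond the scatter.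

Compound 4 `CCCc1cc(-c2ccc(F)cc2)n(Cc2ccc(C(=O)NO)cc2)n1` is not yet measured. It differs from compound 2 by ethyl in place of phenyl on a saturated chain carbon bound to an aromatic carbon; cut one bond further out, benzyl becomes propyl. Compound 1, carrying methyl at that position, sits far lower than compound 2, so a shorter chain is expected to move the number down beyond the scatter, with the step from compound 2 to compound 4 estimated at an 11-fold lower number from compound 2 to compound 4 (1.02 log units; beyond the scatter). For compound 4 the expected value in this assay is 40 nM, with a range from 10 nM to 160 nM.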

Compound 4, half-maximal inhibitory concentration: 167 nM
Compound 4: the middle estimate sits 4.2-fold (0.62 log units) below what was measured, outside the stated range (above it).
By their numbers in this assay, from the lowest: compound 3; then compound 1; then compound 4; then compound 2.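

Benzyl to propyl gives a 2.5-fold lower number from compound 2 to compound 4 (0.40 log units; beyond the scatter) in this assay, the first comparison in the series that changes only this position. With ethyl in place of phenyl on the saturated chain carbon, the number moves beyond the scatter, but only modestly. The data shown give no explanation for this step.

Compound 1 differs from compound 2 and compound 4 in more than one place, so it does not extend this comparison. Two compounds define no trend, leaving open how a longer chain such as pentyl, or a chain ending in an amine, would read here.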